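Tail variation on a shared core: notes toward compound 3

The source may report more compounds than this note shows. Statements on the series, on what has been measured and on what is new or still open speak of the compounds shown alone.

Measured so far in an assay on isolated protein for inhibition of E3 ubiquitin-protein ligase Mdm2 (Homo sapiens), read by fluorescence polarization, with a stated time of 30 min; a lower number here means a stronger inhibitor, a higher number a weaker inhibitor:
compound 1 `CCOc1cc(C(C)(C)C)ccc1C1=NC(c2ccc(Cl)cc2)C(c2ccc(Cl)cc2)N1C(=O)NCCCCCCCC(=O)NO` gives 340 nM
compound 2 `CCOc1cc(C(C)(C)C)ccc1C1=NC(c2ccc(Cl)cc2)C(c2ccc(Cl)cc2)N1C(=O)NCc1ccc(C(=O)NO)cc1` gives 580 nM

For the measured compounds named here, compound 1 holds the lower of the two numbers, compound 2 being nearest; the one measured step, a 1.7-fold higher number from compound 1 to compound 2 (0.23 log units; within the scatter), lies within the scatter, so the two tails are not separable in this assay. Compound 3 `CCOc1cc(C(C)(C)C)ccc1C1=NC(c2ccc(Cl)cc2)C(c2ccc(Cl)cc2)N1C(=O)NCCCCC(=O)Nc1ccccc1N` awaits measurement in this assay. It differs from compound 1 by (2-aminophenyl)carbamoyl in place of 3-(hydroxycarbamoyl)propyl on a saturated chain carbon, four bonds along the chain from an amide-type nitrogen. Going by the values given here, only that small tail step bears on this change, so a step of similar size, or none beyond the scatter, is expected, weaker binding being slightly more likely. For compound 3 the expected step is a 1.2-fold higher number from compound 1 to compound 3 (0.09 log units; within the scatter). Compound 3 is estimated at 420 nM, between 150 nM and 1200 nM.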

Compound 3, inhibition constant: 960 nM
Beside the measured number, compound 3's estimate is 2.3-fold (0.36 log units) below it; measured number inside the range.
By their numbers in this assay, from the lowest: compounds 1, 2 and 3 (each within the scatter of the next, the first and the last beyond it).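

In this assay, for the compounds shown here, (2-aminophenyl)carbamoyl in place of 3-(hydroxycarbamoyl)propyl gives the first tail step beyond the scatter (a 2.8-fold higher number from compound 1 to compound 3 (0.45 log units; beyond the scatter)). Tail changes at this place can therefore register in binding, though modestly, and a hydroxycarbamoyl end is not needed for measurable binding. No measurement at hand accounts for the step.

Chain length and end group change together here, so their contributions remain unseparated. A carboxylic acid on the chain of compound 1, or the 2-aminophenyl amide on a longer chain, would bear on this.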